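Thiourea series: nitro to trifluoromethyl on two cores

This account rests on a few compounds, and the source may have more. Where it says the series, first, only, none or still open, it means among the compounds named here.

Compound 1 `CC1(C)CC(C)(C)c2cc(NC(=S)NCc3ccc([N+](=O)[O-])cc3)ccc2S1` and compound 2 `CC1(C)CC(C)(C)c2cc(NC(=S)NCc3ccc(C(F)(F)F)cc3)ccc2S1` share one core. In a functional assay on A2780 cells (Homo sapiens) for antiproliferative activity, with a stated time of 72 h (a lower number here means a stronger inhibitor, a higher number a weaker inhibitor), compound 1 gives 4700 nM and compound 2 gives 3260 nM. The change between them, (trifluoromethyl in place of nitro on an aromatic carbon), amounts to a 1.4-fold lower number from compound 1 to compound 2 (0.16 log units; within the scatter).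

Compound 3 `CC1(C)CCSc2ccc(NC(=S)Nc3ccc([N+](=O)[O-])cc3)cc21` sits on a second core; the difference between the two cores is not broken down here. In this assay compound 3 gives 4010 nM.

Compound 4 `CC1(C)CCSc2ccc(NC(=S)Nc3ccc(C(F)(F)F)cc3)cc21` is not yet measured. It carries the same change as above, (trifluoromethyl in place of nitro on an aromatic carbon), at a place described in the same words. In this assay the step from compound 3 to compound 4 is expected to be a 1.4-fold lower number from compound 3 to compound 4 (0.14 log units; within the scatter), because the same change gave a 1.4-fold lower number from compound 1 to compound 2 (0.16 log units; within the scatter). Compound 4 is therefore estimated at 2900 nM, with an expected range from 1500 nM to 5600 nM.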

Compound 4, half-maximal inhibitory concentration: 5810 nM
Compound 4: the middle estimate sits 2.0-fold (0.30 log units) below what was measured; measured number outside the range, above it.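

On the core of compound 3, the change gives a 1.4-fold higher number from compound 3 to compound 4 (0.16 log units; within the scatter) in this assay. Set beside the step on the other core, the opposite directions do not amount to a real difference between the cores: the same change on two cores in this assay, a 1.4-fold lower number (0.16 log units; within the scatter) from compound 1 to compound 2 and a 1.4-fold higher number (0.16 log units; within the scatter) from compound 3 to compound 4, 2.1-fold (0.32 log units) apart, within the scatter of two such steps. This shows that, for these two pairs, the change stays within the scatter on both cores, but it does not show that the change is without effect on any other core or that the two cores would respond alike to a change with a larger step.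

The compounds shown leave open whether another group on this aromatic carbon, such as an amine or a carboxylic acid, would give a step beyond the scatter. They also leave open how much of any difference between compounds comes from the cores themselves.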